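Swapping fluoro for methoxy on the 3-substituted phenyl ring

The source may hold more compounds than are shown below. What is called first, only, known or untested is meant among the compounds shown, and "the series" means these compounds.

Of the compounds shown here, three share one core and have been tested in a functional assay on HCT-116 cells (Homo sapiens) for cytotoxicity, with a stated time of 48 h; on this read-out higher numbers stand for weaker inhibition and lower numbers for stronger inhibition. Compound 1, `O=[N+]([O-])c1ccc(CN2CCC(n3cc(CC(OCc4cc(-c5ccc(F)cc5)no4)c4ccc(Br)cc4)nn3)CC2)cc1`, gives only a limit of the assay in this assay, > 25000 nM. Compound 2, `N#Cc1ccc(-c2cc(COC(Cc3cn(C4CCN(Cc5ccc([N+](=O)[O-])cc5)CC4)nn3)c3ccc(Br)cc3)on2)cc1`, likewise gives only a limit in this assay, > 25000 nM. Among the compounds with values here, compound 3, `O=[N+]([O-])c1ccc(CN2CCC(n3cc(CC(OCc4cc(-c5cccc(F)c5)no4)c4ccc(Br)cc4)nn3)CC2)cc1`, is the one compound with a measured number: in this assay compound 3 gives 6000 nM, so it stands as the only real value among the three. Moving the fluoro from a 4-fluorophenyl to a 3-fluorophenyl ring gave an at least 4.1-fold lower number from compound 1 to compound 3 (0.61 log units; beyond the scatter), and replacing 4-cyanophenyl by 3-fluorophenyl gave an at least 4.1-fold lower number from compound 2 to compound 3 (0.61 log units; beyond the scatter); the change from compound 1 to compound 2 is a step that the two limits leave unreadable from compound 1 to compound 2.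

Compound 4, `COc1cccc(-c2cc(COC(Cc3cn(C4CCN(Cc5ccc([N+](=O)[O-])cc5)CC4)nn3)c3ccc(Br)cc3)on2)c1`, differs from compound 3 only in methoxy in place of fluoro on an aromatic carbon. None of the measured steps exchanges one group for another at this position of the ring, so nothing shown speaks directly to the size or direction of this change. The safest expectation is therefore a step of no change at the digits printed from compound 3 to compound 4 (within the scatter) from compound 3 to compound 4, with wide uncertainty. Compound 4 is estimated to give 6000 nM in this assay, expected to lie between 1500 nM and 25000 nM.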

Compound 4, half-maximal inhibitory concentration: > 25000 nM
Compound 4 was reported as a limit (the forecaster's own chance of this, stated with the estimate: 35%); at least 4.1-fold (0.61 log units) between middle value and limit.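

In this assay, the exchange of 3-fluorophenyl for 3-methoxyphenyl gives an at least 4.1-fold higher number from compound 3 to compound 4 (0.61 log units; beyond the scatter), and this is the first step shown in which the group is replaced while its place on the ring, meta to a large group, stays the same; it shows that a measurable value at this place does not survive every exchange of the fluoro. The entry for compound 4 is a limit of the assay, not a number. The steps from compound 1 and from compound 2 to compound 4 cannot be read, and compound 3 remains the only compound that stands clear of the shared limit: the limit of > 25000 nM in this assay, at which 3 of the 4 values shown sit.

From the compounds shown here alone, what a methyl, a chloro or a hydroxyl group would give at this same place remains open, so the fluoro of compound 3 could be a rare fit or merely one of several groups that allow a measurable value. Also open, going by these compounds, is how far the true value of compound 4 lies from its limit, and therefore how large this step really is.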